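This account rests on a few compounds, and the source may have more. Where it says the series, first, only, none or still open, it means among the compounds named here.

Measured so far in a functional assay on HCT-116 cells (Homo sapiens) for inhibition, read by MTT assay, with a stated time of 48 h; a lower number here means a stronger inhibitor, a higher number a weaker inhibitor:
compound 1 `COc1ccc(CN(C(=O)C=C(C)C)c2cc(OC)c(OC)c(OC)c2)cc1O`, 290 nM
compound 2 `C/C=C/C(=O)N(Cc1ccc(OC)c(N)c1)c1cc(OC)c(OC)c(OC)c1`, 300 nM
compound 3 `CCC/C=C/C(=O)N(Cc1ccc(OC)c(O)c1)c1cc(OC)c(OC)c(OC)c1`, 95 nM

Compound 3 gives the lowest number of the three in this assay; compound 1 and compound 2 both sit well above it. Compound 4 `C/C=C/C(=O)N(Cc1ccc(OC)c(O)c1)c1cc(OC)c(OC)c(OC)c1` is the next member: hydrogen in place of ethyl on a saturated chain carbon bound to a double-bonded chain carbon. Among the measured compounds shown here, the only step that speaks to the alkenyl group on the carbonyl is a 3.1-fold lower number from compound 1 to compound 3 (0.48 log units; beyond the scatter), where a longer chain went with a lower number. Compound 2, which carries prop-1-en-1-yl together with an amine, gives 300 nM. Shortening the chain back to prop-1-en-1-yl in compound 4 is therefore expected to raise the number, giving a 2.6-fold higher number from compound 3 to compound 4 (0.42 log units; beyond the scatter). The expected value for compound 4 is 250 nM, within 100 nM to 600 nM.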

Compound 4, half-maximal inhibitory concentration: 55 nM
Estimate against measurement, compound 4: 4.5-fold (0.66 log units) above, outside the stated range (below it).
By their numbers in this assay, from the lowest: compounds 4 and 3 (each within the scatter of the next); then compounds 1 and 2 (each within the scatter of the next).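

In this assay, prop-1-en-1-yl and pent-1-en-1-yl on the carbonyl cannot be told apart (a 1.7-fold lower number from compound 3 to compound 4 (0.24 log units; within the scatter)), so the gain seen for the longer chain does not extend to this shorter one. The branched 2-methylprop-1-en-1-yl group reads higher than prop-1-en-1-yl (a 5.3-fold lower number from compound 1 to compound 4 (0.72 log units; beyond the scatter)), and amino reads higher than hydroxy on the aromatic carbon (a 5.5-fold lower number from compound 2 to compound 4 (0.74 log units; beyond the scatter)). No available evidence accounts for these steps.

Still open, going by these compounds, is how a longer chain such as hept-1-en-1-yl, or a saturated propyl group on the carbonyl, would read. Also open, on these data alone, is whether fluoro on that aromatic carbon would sit nearer hydroxy or amino.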